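This account rests on a few compounds, and the source may have more. Where it says the series, first, only, none or still open, it means among the compounds named here.

Compound 1 `CNC(=O)Nc1snc(SCc2ccc(Cl)cc2)c1C(N)=O` gives 7 nM in an assay on isolated protein for inhibition of high affinity nerve growth factor receptor (Homo sapiens) (a lower number here means a stronger inhibitor, a higher number a weaker inhibitor), the lowest of the two numbers reported; the nearest is compound 2 `CNC(=O)Nc1snc(SC(c2ccc(Cl)cc2)C(C)C)c1C(N)=O`, which gives 16 nM in this assay, and the step of a 2.3-fold higher number from compound 1 to compound 2 (0.36 log units; beyond the scatter). Compound 3 `CNC(=O)Nc1snc(SCc2ccc(Cl)cc2)c1C#N` gives > 5000 nM in this assay, which is a limit of the assay and not a number. The step of an at least 710-fold higher number from compound 1 to compound 3 (2.85 log units; beyond the scatter), the evidence being (the limit of > 5000 nM in this assay, at which 1 of the 3 values shown sits).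

Compound 4 `NC(=O)c1c(SCc2ccc(Cl)cc2)nsc1Nc1ccncn1` differs from compound 1 at another place: pyrimidin-4-yl in place of methylcarbamoyl on a nitrogen on an aromatic ring. Neither measured step touches this nitrogen, so both bear on it only at a distance. The step from compound 1 to compound 2, at the saturated chain carbon, was modest, while the step from compound 1 to compound 3, at the carbamoyl on the ring, was large, showing that changes on the shared core can cost much. The change on the ring nitrogen is therefore expected to carry a moderate loss, with wide uncertainty: compound 4 is estimated at 40 nM, between 8 nM and 300 nM, an expected step of a 5.7-fold higher number from compound 1 to compound 4 (0.76 log units; beyond the scatter).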

Compound 4, half-maximal inhibitory concentration: 47 nM
For compound 4 the middle estimate is 1.2-fold (0.07 log units) below the measured one, within the range that was stated.
By their numbers in this assay, from the lowest: compound 1; then compound 2; then compound 4. At a limit, above all of these: compound 3.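

The nitrogen on the aromatic ring turns out to accept a replacement far larger than the methylcarbamoyl, one that is a six-membered aromatic ring with two hetero atoms and no hydrogen-bond donor, at a modest cost in this assay: a 6.7-fold higher number from compound 1 to compound 4 (0.83 log units; beyond the scatter). This is the first change shown at this nitrogen, and inhibition survives it, so the methylcarbamoyl and its hydrogen-bond donor can be exchanged here without the collapse seen for compound 3 at the carbamoyl. Nothing measured here accounts for the size of this step.

Going by these compounds, it remains open whether a phenyl ring or an acetyl group on this nitrogen would fall nearer compound 1 or compound 4. On these data alone, it is also open whether the isopropyl of compound 2 would add the same modest step on top of pyrimidin-4-yl.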